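Aryl Swap on a Nucleoside Core: Compound 3 to Compound 4

The compounds below may be only part of what the source reports. "The series", "measured", "known", "first", "only" and "open" are said of these compounds alone.

Measured so far in a functional assay on HCT-116 cells (Homo sapiens), read by MTT assay, with a stated time of 72 h; on this read-out lower numbers stand for stronger inhibition and higher numbers for weaker inhibition:
compound 1 `Nc1nc(N)c2c(-c3ccsc3)cn([C@@H]3O[C@H](CO)[C@@H](O)[C@H]3O)c2n1` — a limit only, > 20000 nM
compound 2 `CNc1ncnc2c1c(-c1ccccc1)cn2[C@@H]1O[C@H](CO)[C@@H](O)[C@H]1O` — a limit only, > 100000 nM
compound 3 `Cc1nc(N)c2c(-c3ccsc3)cn([C@@H]3O[C@H](CO)[C@@H](O)[C@H]3O)c2n1` — a limit only, > 20000 nM

Compound 3 stands at a limit of this assay and not at a number. The two further values are limits as well: the limit of > 20000 nM in this assay, at which 2 of the 3 values shown sit, (the limit of > 100000 nM in this assay, at which 1 of the 3 values shown sits). Within the data shown here, the one measured step that touches compound 3, a step that the two limits leave unreadable from compound 1 to compound 3, runs between two limits and its size cannot be read.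

The change to compound 4 `Cc1nc(N)c2c(-c3ccccc3)cn([C@@H]3O[C@H](CO)[C@@H](O)[C@H]3O)c2n1` is phenyl in place of thiophen-3-yl on an aromatic carbon. Among the measured compounds shown here, no measured step covers this change. For the measured compounds named here, compound 2 carries phenyl at the same place, with methylamino elsewhere on the shared core, and its value is a limit too; it shows no numeric gain from phenyl, but also no step that can be sized.

With every anchor at a limit, the expectation for compound 4 is that this assay again reports a limit rather than a number, so the step that the limit leaves unreadable from compound 3 to compound 4 is estimated as not readable beyond the scatter. Compound 4 is therefore expected at 60000 nM, within 20000 nM to 200000 nM.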

Compound 4, half-maximal inhibitory concentration: > 20000 nM
Compound 4: no number, only a limit; the forecaster's own chance of this, stated with the estimate: 85%; the middle value does not contradict the limit.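

In this assay compound 4 gives > 20000 nM, which is a limit. With compound 3 also at a limit, no step can be read between compound 3 and compound 4 for phenyl in place of thiophen-3-yl. The compounds shown leave open whether either group on the shared core can give a numeric value in this assay.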